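Adding to the chain from compound 2 to compound 3

The source may hold more compounds than are shown below. What is called first, only, known or untested is meant among the compounds shown, and "the series" means these compounds.

- Compound 1 `CCCCCCCCCn1cc(COC[C@@H]2OC[C@H](N)[C@@H]2O)nn1` gives 12400 nM
- Compound 2 `CCCCCCCCCCn1cc(COC[C@@H]2OC[C@H](N)[C@@H]2O)nn1` gives 9640 nM

Among the compounds with values here, both values come from a functional assay on MCF7 cells (Homo sapiens) for antiproliferative activity, read by MTT assay, with a stated time of 48 h (a lower number here means a stronger inhibitor, a higher number a weaker inhibitor), and are the only numbers measured so far. They stand too close together to rank: a 1.3-fold lower number from compound 1 to compound 2 (0.11 log units; within the scatter) is a step that repeated measurements could produce by themselves. Compound 2 therefore sits level with compound 1 on present evidence.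

Compound 3 `CCCCCCCCCCCCn1cc(COC[C@@H]2OC[C@H](N)[C@@H]2O)nn1` keeps the shared core and differs from compound 2 only on the chain, through the change ethyl in place of hydrogen on a saturated chain carbon, ten or more bonds along the chain from an aromatic nitrogen and nothing else.

Within the data shown here, one measured step bears on this change, a methyl in place of hydrogen on the same chain. That step is small and gives only a weak hint of direction. The new group is larger, so a modest move toward a lower number in this assay is expected, with no firm step beyond the scatter. The expected change is a 1.5-fold lower number from compound 2 to compound 3 (0.17 log units; within the scatter) and it may prove too small to distinguish. Compound 3 is estimated at 6500 nM with an expected range from 2800 nM to 13000 nM in this measurement.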

Compound 3, half-maximal inhibitory concentration: 2210 nM
Compound 3: middle estimate off by 2.9-fold (0.47 log units), on the high side; measured number below the stated range.
By their numbers in this assay, from the lowest: compound 3; then compounds 2 and 1 (each within the scatter of the next).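

In this assay, within the data shown here, the ethyl in place of hydrogen at this place on the chain brings a 4.4-fold lower number from compound 2 to compound 3 (0.64 log units; beyond the scatter) and so gives the first step on this chain that clearly exceeds the noise, something the smaller methyl step from compound 1 to compound 2 did not do. The comparison with the shortest chain shown, a 5.6-fold lower number from compound 1 to compound 3 (0.75 log units; beyond the scatter), points the same way, which makes compound 3 the most potent of the set, since its steps to both other compounds lie beyond the scatter, while compounds 1 and 2 still cannot be ranked against each other and so do not show a steady gain with each added carbon. Nothing measured here explains why the number falls with this longer chain.

These compounds cannot show whether a still longer chain would lower the number further or raise it again. They also leave open whether an amine or a carboxylic acid in place of the ethyl, at this same place on the chain, would keep the lower number.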